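Compound 1 to compound 3: a new aromatic group

The source may report more compounds than this note shows. Statements on the series, on what has been measured and on what is new or still open speak of the compounds shown alone.

compound 1 `Cn1nccc1-c1cnc(NCc2c(F)ccc3c2CCO3)c2cn[nH]c(=O)c12` in a physicochemical assay for lipophilicity, using the shake flask method, in phosphate buffer, measured as octanol-water partition, with a stated time of 30 min, at pH 7.4; a lower number here means a more polar compound, a higher number a more lipophilic compound: 2.6
compound 2 `Cc1ncccc1-c1cnc(NCc2c(F)ccc3c2CCO3)c2ncc(=O)[nH]c12` in this assay: 2.8

Compound 1 at 2.6 and compound 2 at 2.8 lie within the scatter of each other, so these two compounds cannot be put in order. The step followed here leads from compound 1 to compound 3 `Cc1ncccc1-c1cnc(NCc2c(F)ccc3c2CCO3)c2cn[nH]c(=O)c12` which is still unmeasured. The change is 2-methylpyridin-3-yl in place of 1-methyl-1H-pyrazol-5-yl on an aromatic carbon with 2-methylpyridin-3-yl in place of 1-methyl-1H-pyrazol-5-yl on an aromatic carbon, and the rest of compound 1 stays as it is.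

Among the measured compounds shown here, no step between measured compounds isolates this change, so the data offer no direct measure of its size. The nearest evidence is compound 2, which carries 2-methylpyridin-3-yl on a different core and gives 2.8 in this assay as a single reference point. A small rise is expected, not clearly beyond the scatter. The estimate is a number 0.20 log units higher from compound 1 to compound 3 (within the scatter) and it remains a modest expected move. In this assay the expected value for compound 3 is 2.8 with an estimated range of 2.4 to 3.2 for the measurement still to come.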

Compound 3, distribution coefficient: 3
Compound 3: the middle estimate sits 0.20 log units below what was measured, and the stated range covers the measured number.
By their numbers in this assay, from the lowest: compounds 1, 2 and 3 (each within the scatter of the next, the first and the last beyond it).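

Among the compounds shown, this is the first comparison that isolates a single change, and it concerns the aromatic carbon para to a large group on the core of compound 1. In this assay, 2-methylpyridin-3-yl in place of 1-methyl-1H-pyrazol-5-yl gives a number 0.40 log units higher from compound 1 to compound 3 (beyond the scatter), so the choice of aromatic group at this position shifts the read-out by more than repeat measurements would. The change replaces one five-membered aromatic ring with 2 hetero atoms by one six-membered aromatic ring with 1 hetero atom, and it also alters the heavy-atom and acceptor counts, but nothing available shows which of these differences accounts for the step.

As far as these compounds go, whether a step of this size carries over to the core of compound 2 remains open, as does the separate contribution of the methyl group on the pyridine ring. Also open, from the compounds shown here alone, is how the read-out responds when the same aromatic carbon carries an amine or a carboxylic acid in place of either aromatic group.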